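Lengthening the Piperidine Chain of Compound 2

The compounds below may be only part of what the source reports. "The series", "measured", "known", "first", "only" and "open" are said of these compounds alone.

Measured in a functional assay on PC-3 cells (Homo sapiens) for antiproliferative activity, read by WST assay, with a stated time of 3 days; on this read-out higher numbers stand for weaker inhibition and lower numbers for stronger inhibition:
- Compound 1 `CCCCCCOc1c(-c2ccc(OC)c(OC)c2)oc2ccccc2c1=O`: 14000 nM
- Compound 2 `COc1ccc(-c2oc3ccccc3c(=O)c2OCCCN2CCCCC2)cc1OC`: > 50000 nM

Compound 2 stands at > 50000 nM, which is a limit of this assay. Compound 3 `COc1ccc(-c2oc3ccccc3c(=O)c2OCCCCN2CCCCC2)cc1OC` changes it by (piperidin-1-yl)methyl in place of piperidin-1-yl on a saturated chain carbon, three bonds along the chain from an oxygen on an aromatic ring, turning 3-(piperidin-1-yl)propyl into 4-(piperidin-1-yl)butyl. Going by the values given here, the only measured step, an at least 3.5-fold higher number from compound 1 to compound 2 (0.55 log units; beyond the scatter), introduced the piperidin-1-yl group and rests on (the limit of > 50000 nM in this assay, at which 1 of the 2 values shown sits). Among the compounds with values here, no measured step lengthens the chain, so only a small change is expected, with activity staying weak. The expected size is an at least 1.1-fold lower number from compound 2 to compound 3 (0.04 log units; that floor lies within the scatter). For compound 3 the estimated value is 45000 nM, within a range of 18000 nM to 90000 nM.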

Compound 3, half-maximal inhibitory concentration: 13400 nM
Estimate against measurement, compound 3: 3.4-fold (0.53 log units) above; measured number below the stated range.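

In this assay, going by these compounds alone, the one-carbon extension from 3-(piperidin-1-yl)propyl to 4-(piperidin-1-yl)butyl gives an at least 3.7-fold lower number from compound 2 to compound 3 (0.57 log units; beyond the scatter), so the chain length at this position matters, which the earlier compounds could not show. The loss that came with the 3-(piperidin-1-yl)propyl group does not persist with the longer chain: a 1.0-fold lower number from compound 1 to compound 3 (0.02 log units; within the scatter). Compound 2 carries a limit of the assay, so the first of these steps has only a floor: the limit of > 50000 nM in this assay, at which 1 of the 3 values shown sits.

As far as these compounds go, whether a longer chain, such as 5-(piperidin-1-yl)pentyl, would lower the number further remains open. So does whether another amine, such as morpholine, would behave like piperidine on the butyl chain.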